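This account rests on a few compounds, and the source may have more. Where it says the series, first, only, none or still open, it means among the compounds named here.

Measured so far in an ADME assay on microsomes from liver (Homo sapiens) for metabolic stability, read by LC-MS, with a stated time of 40 min, tested at 0.5 uM; on this read-out higher numbers stand for fast clearance and lower numbers for slow clearance:
Compound 1 `O=C(Nc1cccc(S(=O)(=O)C2COC2)c1)c1cccnc1N1CCC2(CC1)CC2`: compound 1 gives 183 mL.min-1.g-1.
Compound 2 `O=C(Nc1cccc(S(=O)(=O)C2CCCC2)c1)c1cccnc1N1CCC(F)(F)CC1`: for compound 2 only a limit is reported, > 399 mL.min-1.g-1.
Compound 3 `O=C(Nc1cccc(S(=O)(=O)N2CCCCC2)c1)c1cn[nH]c1-c1ccc(Cl)cc1`: compound 3 gives 255 mL.min-1.g-1.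

Compound 2 stands at the fast end of the three values, and its entry is a limit of this assay rather than a number (the limit of > 399 mL.min-1.g-1 in this assay, at which 1 of the 3 values shown sits). Among the measured compounds shown here, no step between two measured compounds is available in this set, so no measured change can be drawn on directly.

The step to compound 4 `O=C(Nc1cccc(S(=O)(=O)C2CCCC2)c1)c1cccnc1N1CCC2(CC1)CC2` is a group of 8 heavy atoms (7 carbon, 1 nitrogen; one three-membered non-aromatic ring of carbon only, one six-membered non-aromatic ring with 1 hetero atom) in place of a group of 8 heavy atoms (5 carbon, 1 nitrogen, 2 fluorine; one six-membered non-aromatic ring with 1 hetero atom), on an aromatic carbon. Compound 1 carries that same entering group beside a different sulfone and gives 183 mL.min-1.g-1 in this assay, a number rather than a limit. On that basis the expectation for this assay is a step downward from compound 2 to compound 4 of uncertain size, likely modest and possibly within the scatter, since the starting point is itself only a limit: expected an at least 1.2-fold lower number from compound 2 to compound 4 (0.09 log units; that floor lies within the scatter). Compound 4 is therefore estimated at 320 mL.min-1.g-1, with a range of 150 mL.min-1.g-1 to 700 mL.min-1.g-1, and a real chance that this assay again reports only a limit.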

Compound 4, intrinsic clearance in microsomes: > 399 mL.min-1.g-1
Compound 4: only a limit was reported; the forecaster's own chance of this, stated with the estimate: 40%; middle value at least 1.2-fold (0.09 log units) away from the limit.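

The step from compound 2 to compound 4 cannot be read, as both entries in this assay are limits rather than numbers: the limit of > 399 mL.min-1.g-1 in this assay, at which 2 of the 4 values shown sit. Among the compounds shown here, the sulfonyl position gives the first readable change: cyclopentyl in place of oxetan-3-yl on a sulfonyl sulfur gives an at least 2.1-fold higher number from compound 1 to compound 4 (0.33 log units; beyond the scatter), beyond the scatter, with the same group on the aromatic carbon next to the ring nitrogen. Compound 4 is itself a limit, so this step has a floor and no measured size.

Still open, going by these compounds, is how 4,4-difluoropiperidin-1-yl behaves when paired with oxetan-3-yl on the sulfonyl sulfur, a pairing that would allow a one-place comparison with compound 1. Also open, on these data alone, is whether a methyl group or a tetrahydropyran-4-yl group on that sulfur would give a number rather than a limit.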